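The source may hold more compounds than are shown below. What is called first, only, known or untested is meant among the compounds shown, and "the series" means these compounds.

Compound 1 `C=C1C(=O)O[C@H]2[C@H]1CC/C(COC(=O)N1CCC(F)(F)CC1)=C\CC[C@@]1(C)O[C@@H]21`: 1410 nM
Compound 2 `C=C1C(=O)O[C@H]2[C@H]1CC/C(COC(=O)NCCN1CCCC1)=C\CC[C@@]1(C)O[C@@H]21`: 3180 nM

Both compounds were tested in a functional assay on HCT-116 cells (Homo sapiens) for inhibition; on this read-out higher numbers stand for weaker inhibition of growth and lower numbers for stronger inhibition of growth. Compound 2 holds the higher of the two numbers, at 3180 nM, and so shows the weaker inhibition of growth. Among the compounds with values here, its only neighbour is compound 1, at 1410 nM, and the gap between them lies beyond the usual scatter.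

The next compound to be tested is compound 3 `C=C1C(=O)O[C@H]2[C@H]1CC/C(COC(=O)Nc1n[nH]c(SC)n1)=C\CC[C@@]1(C)O[C@@H]21`. It keeps the shared core of compound 2 and changes one group: 5-(methylsulfanyl)-1H-1,2,4-triazol-3-yl in place of 2-(pyrrolidin-1-yl)ethyl on an amide-type nitrogen. In words, 5-(methylsulfanyl)-1H-1,2,4-triazol-3-yl stands in place of 2-(pyrrolidin-1-yl)ethyl on an amide-type nitrogen.

Within the data shown here, only one measured step bears on this change: a 2.3-fold higher number from compound 1 to compound 2 (0.35 log units; beyond the scatter). That modest step also replaces the 2-(pyrrolidin-1-yl)ethyl-bearing group, but neither measured compound carries the entering triazole, so the evidence is thin. A modest step is therefore expected, toward a lower number, as compound 2 already sits at the top of this small range.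

The expected change is a 1.9-fold lower number from compound 2 to compound 3 (0.27 log units; within the scatter), and it may not clear the scatter. For compound 3 the estimated value is 1700 nM, with an expected range from 600 nM to 4500 nM.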

Compound 3, concentration for 50% growth inhibition: 1130 nM
For compound 3 the middle estimate is 1.5-fold (0.18 log units) above the measured one, and the stated range covers the measured number.
By their numbers in this assay, from the lowest: compounds 3 and 1 (each within the scatter of the next); then compound 2.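

On the amide-type nitrogen, this assay responds to the exchange of 2-(pyrrolidin-1-yl)ethyl for 5-(methylsulfanyl)-1H-1,2,4-triazol-3-yl with a 2.8-fold lower number from compound 2 to compound 3 (0.45 log units; beyond the scatter), a modest shift beyond the scatter, and the two groups count the same number of heavy atoms, so this shift comes without any change in that count. Set against the 4,4-difluoropiperidin-1-yl on the carbonyl carbon, the (5-(methylsulfanyl)-1H-1,2,4-triazol-3-yl)amino group gives a 1.2-fold lower number from compound 1 to compound 3 (0.10 log units; within the scatter), so these two very different groups cannot be told apart here, and among the three compounds only compound 2 stands apart from the others. Nothing measured here speaks to what lies behind this shift.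

The compounds shown leave open whether the value of compound 3 rests on the triazole ring itself or on its methylsulfanyl group, a question that a triazole carrying a hydrogen, a methoxy group or a phenyl ring in that place would address. They also leave open whether the higher number of compound 2 belongs to the pyrrolidine ring or to the ethyl chain, which a 2-(dimethylamino)ethyl or a 3-(pyrrolidin-1-yl)propyl group would help to separate.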